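The compounds below may be only part of what the source reports. "The series", "measured", "known", "first", "only" and "open" are said of these compounds alone.

Compound 1, `COc1cc(/C=C/C(=O)c2cccc(-n3cc(-c4ccc(Cl)cc4)[nH]c3=O)c2)cc(OC)c1OC`: in a functional assay on PC-3 cells (Homo sapiens) for inhibition (on this read-out higher numbers stand for weaker inhibition of growth and lower numbers for stronger inhibition of growth), compound 1 is recorded as "not active" (no number reported), with no concentration given.
Compound 2, `COc1cc(/C=C/C(=O)c2cccc(-n3cc(-c4ccccc4)[nH]c3=O)c2)ccc1O`: 2520 nM in this assay.

For the measured compounds named here, compound 2 thus holds the only number in this assay; compound 1 stands beside it without a value, described only as inactive. The two differ at more than one place, so their comparison says nothing about any single change.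

Compound 3, `O=C(/C=C/c1cccc(O)c1)c1cccc(-n2cc(-c3ccccc3)[nH]c2=O)c1`, is the compound still to be measured in this assay. It differs from compound 2 by 3-hydroxyphenyl in place of 4-hydroxy-3-methoxyphenyl on a double-bonded chain carbon bound to a double-bonded chain carbon. The entering 3-hydroxyphenyl is the smaller of the two groups, with 7 heavy atoms against 9 and 1 hydrogen-bond acceptor against 2, while the single hydrogen-bond donor is kept.

Going by the values given here, no measured pair shows this change, so its size is uncertain. The expectation is a modest loss of growth inhibition for compound 3 relative to compound 2, a step of a 1.6-fold higher number from compound 2 to compound 3 (0.20 log units; within the scatter) that may well sit at the edge of the usual scatter. On that basis compound 3 is estimated at 4000 nM in this assay, within a range from 1200 nM to 13000 nM.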

Compound 3, concentration for 50% growth inhibition: 2820 nM
Compound 3: middle estimate off by 1.4-fold (0.15 log units), on the high side, and the stated range covers the measured number.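

In this assay, for the compounds shown here, this is the first comparison of compounds that differ in one place: 3-hydroxyphenyl in place of 4-hydroxy-3-methoxyphenyl on a double-bonded chain carbon bound to a double-bonded chain carbon gives a 1.1-fold higher number from compound 2 to compound 3 (0.05 log units; within the scatter). The read-out therefore does not separate the two groups, although the entering group has 7 heavy atoms against 9 and 1 hydrogen-bond acceptor against 2, while the single hydrogen-bond donor is kept. The data offer no measurement that could explain this result.

Going by these compounds alone, these two compounds cannot show whether the methoxy group and the relocated hydroxyl each matter alone or whether their contributions offset each other, since both differences fall within the one exchange. On these data alone, how the same place would respond to a phenyl group carrying an amine or a carboxylic acid remains open, as does the meaning of compound 1, which has no number and differs from compound 2 at more than one place.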